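A few compounds are considered here, and "the series" means these few. Any claim that something is new, unique, unknown or untested is made for them only; others in the source may bear on it.

Compounds measured in an assay for binding affinity to Alpha-1A adrenergic receptor (Homo sapiens); on this read-out lower numbers stand for stronger inhibition and higher numbers for weaker inhibition:
- compound 1 `COc1cccc(Cc2nn(C[C@H]3CCCN3C)c(=O)c3ccccc23)c1` gives 1580 nM
- compound 2 `CCCCCc1nn(C[C@H]2CCCN2C)c(=O)c2ccccc12` gives 501 nM
- compound 3 `CN1CCC[C@@H]1Cn1nc(Cc2ccc(F)c(F)c2)c2ccccc2c1=O` gives 200 nM

Compound 3 holds the lowest number of the three in this assay; its steps to both others lie beyond the scatter, so it is the strongest binder in this set. The two steps into it are a 2.5-fold lower number from compound 2 to compound 3 (0.40 log units; beyond the scatter) and a 7.9-fold lower number from compound 1 to compound 3 (0.90 log units; beyond the scatter), while between the two weaker compounds the step is a 3.2-fold lower number from compound 1 to compound 2 (0.50 log units; beyond the scatter).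

Compound 4 `CN1CCC[C@@H]1Cn1nc(CC2CCCCC2)c2ccccc2c1=O` differs from compound 3 in one place: cyclohexyl in place of 3,4-difluorophenyl on a saturated chain carbon bound to an aromatic carbon. Among the compounds with values here, the step that bears most on this is the one from compound 2 to compound 3, where a saturated butyl gave way to the 3,4-difluorophenyl; going back from an aromatic ring to a saturated group would be expected to run the other way, giving a higher number in this assay. Cyclohexyl is a ring, unlike butyl, so the shift is expected to be modest rather than large. The estimated step is a 2.0-fold higher number from compound 3 to compound 4 (0.30 log units; within the scatter). For compound 4 the expected value in this assay is 400 nM, with a range from 150 nM to 1100 nM.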

Compound 4, inhibition constant: > 1990 nM
Compound 4: only a limit was reported; the forecaster's own chance of this, stated with the estimate: 3%; middle value at least 4.9-fold (0.69 log units) away from the limit.
By their numbers in this assay, from the lowest: compound 3; then compound 2; then compound 1. At a limit, above all of these: compound 4.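

In this assay, having a ring at this place is not enough to keep the binding of compound 3: cyclohexyl in place of 3,4-difluorophenyl gives an at least 9.9-fold higher number from compound 3 to compound 4 (0.99 log units; beyond the scatter). Saturation alone does not set the number either, with an at least 3.9-fold higher number from compound 2 to compound 4 (0.59 log units; beyond the scatter) for cyclohexyl in place of butyl, while an at least 1.2-fold higher number from compound 1 to compound 4 (0.10 log units; that floor lies within the scatter) leaves compound 4 not clearly separated from the 3-methoxyphenyl compound. The reading for compound 4 is a limit and not a number: the limit of > 1990 nM in this assay, at which 1 of the 4 values shown sits.

From the compounds shown here alone, how far past that limit compound 4 lies remains open, and so does the full size of each of its steps. Also open, going by these compounds, is whether the aromatic ring or its fluorines account for the standing of compound 3, a question that an unsubstituted phenyl at this place would address.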